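Trifluoromethyl in Place of Methoxy on the Anilino Ring

A few compounds are considered here, and "the series" means these few. Any claim that something is new, unique, unknown or untested is made for them only; others in the source may bear on it.

Compound 3 `COc1ccc(Nc2nc3ccccc3nc2S(=O)(=O)c2ccc(C)cc2)cc1` carries a methyl on the sulfonyl-bearing ring and a methoxy on the anilino ring. In a functional assay on PC-3 cells (Homo sapiens) for cytotoxicity, read by MTT assay, with a stated time of 72 h (on this read-out lower numbers stand for stronger inhibition and higher numbers for weaker inhibition), compound 3 reaches only > 50000 nM, which is a limit of the assay and not a number. Compound 1 `COc1ccc(Nc2nc3ccccc3nc2S(=O)(=O)c2ccccc2)cc1` lacks that methyl, and in this assay compound 1 gives 1510 nM. Compound 2 `O=S(=O)(c1ccccc1)c1nc2ccccc2nc1Nc1ccc(Cl)cc1` carries chloro in place of the methoxy, and in this assay compound 2 gives 15300 nM. The step of an at least 33-fold higher number from compound 1 to compound 3 (1.51 log units; beyond the scatter) places compound 3 at the limit of > 50000 nM in this assay, at which 1 of the 3 values shown sits.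

Compound 4 `Cc1ccc(S(=O)(=O)c2nc3ccccc3nc2Nc2ccc(C(F)(F)F)cc2)cc1` differs from compound 3 by trifluoromethyl in place of methoxy on an aromatic carbon. Among the compounds with values here, two measured steps bear on this change. The step of a 10-fold higher number from compound 1 to compound 2 (1.01 log units; beyond the scatter) shows that exchanging the methoxy on the anilino ring for chloro weakened the compound by a large amount. The step of an at least 33-fold higher number from compound 1 to compound 3 (1.51 log units; beyond the scatter) shows that the methyl on the sulfonyl-bearing ring, which compound 4 keeps, already carried the compound past the limit. Both point the same way, so compound 4 is expected to stay at or beyond the limit, with an expected step that the limit leaves unreadable from compound 3 to compound 4 that is at most small. Compound 4 is therefore estimated at 90000 nM, within a range from 25000 nM to 400000 nM.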

Compound 4, half-maximal inhibitory concentration: 2540 nM
Compound 4: the middle estimate sits 35-fold (1.55 log units) above what was measured, and the stated range ends above it.
By their numbers in this assay, from the lowest: compounds 1 and 4 (each within the scatter of the next); then compound 2. At a limit, above all of these: compound 3.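

With the methyl kept on the sulfonyl-bearing ring, the exchange of methoxy for trifluoromethyl on an aromatic carbon gives in this assay an at least 19-fold lower number from compound 3 to compound 4 (1.29 log units; beyond the scatter) and brings the series back from a limit to a measured number, so the methyl does not by itself put this series out of reach of the assay. Compound 3 stands at a limit of the assay and not at a number, so this step gives a bound and not a full size: (the limit of > 50000 nM in this assay, at which 1 of the 4 values shown sits). Leaving methoxy at this place is also not bad in every setting: without the methyl, the exchange for chloro gave a 10-fold higher number from compound 1 to compound 2 (1.01 log units; beyond the scatter) and went the other way, though that pair differs from the new one in both the entering group and the sulfonyl-bearing ring.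

The compounds shown do not pair chloro with the methyl or trifluoromethyl without it, so it stays open whether the reversal belongs to trifluoromethyl itself or to its combination with the methyl. On these data alone, how a nitrile or an amine at this place would read in this assay also remains open.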